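Fluoro in place of trifluoromethyl: working notes on the series

A few compounds are considered here, and "the series" means these few. Any claim that something is new, unique, unknown or untested is made for them only; others in the source may bear on it.

Measured in an ADME assay on cells (Peritoneal macrophage, Mus musculus) for cytotoxicity, read by MTT assay, with a stated time of 24 h; a lower number here means that less compound is tolerated, a higher number that more compound is tolerated:
- compound 1 `COc1ccc(N/C(=N\C(=O)c2ccccc2)NCc2ccccc2)cc1`: 837000 nM
- compound 2 `O=C(/N=C(/NCc1ccccc1)Nc1ccc(C(F)(F)F)cc1)c1ccccc1`: 18600 nM

Compound 2 holds the lower of the two numbers, so less of it is tolerated. Among the compounds with values here, the one measured step is a 45-fold lower number from compound 1 to compound 2 (1.65 log units; beyond the scatter), large and made at the same aromatic carbon, with trifluoromethyl in place of methoxy.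

Still unmeasured is compound 3 `O=C(/N=C(/NCc1ccccc1)Nc1ccc(F)cc1)c1ccccc1`, which differs from compound 2 as follows: fluoro in place of trifluoromethyl on an aromatic carbon. This puts fluoro in place of trifluoromethyl on an aromatic carbon, para to a large group.

Within the data shown here, no measured compound carries fluoro, so the only guide is the step above, which shows that this place can move the number strongly. A position between the two measured compounds is expected, with a higher number in this assay, beyond the scatter. The expected move is a 4.8-fold higher number from compound 2 to compound 3 (0.68 log units; beyond the scatter). For compound 3 the estimate is 90000 nM, with a range of 25000 nM to 350000 nM.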

Compound 3, half-maximal cytotoxic concentration: 866000 nM
Estimate against measurement, compound 3: 9.6-fold (0.98 log units) below; measured number above the stated range.
By their numbers in this assay, from the lowest: compound 2; then compounds 1 and 3 (each within the scatter of the next).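

In this assay the change to fluoro gives a 47-fold higher number from compound 2 to compound 3 (1.67 log units; beyond the scatter) and is large, so the number does not stop partway back towards compound 1. Instead, a 1.0-fold higher number from compound 1 to compound 3 (0.01 log units; within the scatter) and leaves fluoro and methoxy at this aromatic carbon indistinguishable in this measure, while among these three compounds only compound 2, with trifluoromethyl, stands apart. No available evidence accounts for why trifluoromethyl separates from the other two groups.

Still open, as far as these compounds go, is whether the low number belongs to trifluoromethyl alone or also appears with other groups at this carbon, such as a nitrile, an amine or a carboxylic acid. Also open, from the compounds shown here alone, is whether the same large step from trifluoromethyl to fluoro would appear with changes elsewhere in the shared core.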